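A few compounds are considered here, and "the series" means these few. Any claim that something is new, unique, unknown or untested is made for them only; others in the source may bear on it.

Three compounds sharing one core have numbers in a functional assay on LoVo cells (Homo sapiens) for inhibition, read by MTT assay, with a stated time of 24 h; a higher number here means a weaker inhibitor, a lower number a stronger inhibitor. Compound 1 `CC1(C)[C@H]2CC[C@]1(C)N(Cc1cn(-c3ccccc3Br)nn1)C(=O)C2`, with a 2-bromophenyl group, gives 60 nM. Compound 2 `CC1(C)[C@H]2CC[C@]1(C)N(Cc1cn(-c3cccc(C#N)c3)nn1)C(=O)C2`, with a 3-cyanophenyl group, gives 320 nM. Compound 3 `CC1(C)[C@H]2CC[C@]1(C)N(Cc1cn(-c3ccccc3Cl)nn1)C(=O)C2`, with a 2-chlorophenyl group, gives 190 nM. Compound 3 stands clearly apart from compound 1 but not from compound 2, as the record shows a 1.7-fold lower number from compound 2 to compound 3 (0.23 log units; within the scatter).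

Compound 4 `CC1(C)[C@H]2CC[C@]1(C)N(Cc1cn(-c3ccccc3O)nn1)C(=O)C2` carries hydroxy in place of chloro on an aromatic carbon, ortho to a large group: hydroxy in place of chloro on an aromatic carbon. Going by the values given here, no measured step makes this exact swap, and no measured compound carries a hydroxy group. The closest evidence is chloro in place of bromo on an aromatic carbon, which gave a 3.2-fold higher number from compound 1 to compound 3 (0.50 log units; beyond the scatter). The change of the whole aryl group gave a 5.3-fold higher number from compound 1 to compound 2 (0.73 log units; beyond the scatter). Both steps are modest, and both lead away from compound 1 towards a higher number. A modest change is therefore the most that these data suggest, and a result within the scatter seems likeliest, with a slight lean towards a higher number. The expected step is a 1.4-fold higher number from compound 3 to compound 4 (0.14 log units; within the scatter). The estimated value for compound 4 is 260 nM, with an expected range from 80 nM to 800 nM.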

Compound 4, half-maximal inhibitory concentration: 540 nM
Estimate against measurement, compound 4: 2.1-fold (0.32 log units) below, and the stated range covers the measured number.
By their numbers in this assay, from the lowest: compound 1; then compounds 3, 2 and 4 (each within the scatter of the next, the first and the last beyond it).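

In this assay, hydroxy in place of chloro on an aromatic carbon, ortho to a large group, gives a 2.8-fold higher number from compound 3 to compound 4 (0.45 log units; beyond the scatter) and a step beyond the scatter, so the exchange of this single heavy atom is enough to move the number. Hydroxy in place of bromo at the same place gives a 9.0-fold higher number from compound 1 to compound 4 (0.95 log units; beyond the scatter) as the largest step in this set, which shows that bromo, chloro and hydroxy at this one position span a wider range than the two halogens alone revealed. Going by these compounds alone, the single change at this position also brings the number close to that of a compound with a different aryl group, since the record gives a 1.7-fold higher number from compound 2 to compound 4 (0.23 log units; within the scatter) and that step stays within the scatter.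

No measurement in hand explains why these steps take the size they do, so their cause remains unknown. Also open, going by these compounds, is how an amine, a methoxy group or a fluoro group would read at this position, and whether hydroxy would give a similar step at another place on the phenyl ring.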